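A few compounds are considered here, and "the series" means these few. Any claim that something is new, unique, unknown or untested is made for them only; others in the source may bear on it.

Measured so far in a functional assay on LNCaP cells (Homo sapiens) for cytotoxicity; a lower number here means a stronger inhibitor, a higher number a weaker inhibitor:
compound 1 `CNC(=O)Nc1ccc(-c2nc(N3CC4CCC(C3)O4)c3sccc3n2)cc1` gives 85 nM
compound 2 `O=C(Nc1ccc(-c2nc(N3CC4CCC(C3)O4)c3sccc3n2)cc1)Nc1cccnc1` gives 27 nM
compound 3 `CN1CCN(Cc2cc3nc(-c4ccc(NC(=O)Nc5cccnc5)cc4)nc(N4CC5CCC(C4)O5)c3s2)CC1` gives 148 nM

Compound 3 stands highest of the three numbers in this assay; its gap to compound 1 lies within the scatter, while its gap to compound 2 lies beyond it, a 5.5-fold higher number from compound 2 to compound 3 (0.74 log units; beyond the scatter). The other measured step, a 3.1-fold lower number from compound 1 to compound 2 (0.50 log units; beyond the scatter), is the only one that touches the amide-type nitrogen now in question, and it exchanged methyl for pyridin-3-yl rather than one pyridinyl for another.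

Compound 4 `CN1CCN(Cc2cc3nc(-c4ccc(NC(=O)Nc5ccncc5)cc4)nc(N4CC5CCC(C4)O5)c3s2)CC1` differs from compound 3 by pyridin-4-yl in place of pyridin-3-yl on an amide-type nitrogen; the two have the same atoms, joined differently. For the measured compounds named here, no measured pair sets pyridin-3-yl against pyridin-4-yl at this nitrogen, so the two steps in hand give no direction for the change; the step from compound 1 to compound 2 shows only that this nitrogen tolerates a pyridinyl at all. In this assay the expected step is therefore none beyond the scatter, a 1.0-fold higher number from compound 3 to compound 4 (0.01 log units; within the scatter). Compound 4 is estimated at 150 nM in this assay, with a range from 60 nM to 400 nM that is kept wide for want of any isomer comparison.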

Compound 4, half-maximal inhibitory concentration: 200 nM
Beside the measured number, compound 4's estimate is 1.3-fold (0.12 log units) below it; measured number inside the range.
By their numbers in this assay, from the lowest: compound 2; then compounds 1, 3 and 4 (each within the scatter of the next, the first and the last beyond it).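

In this assay, the exchange of pyridin-3-yl for pyridin-4-yl on the amide-type nitrogen gives a 1.4-fold higher number from compound 3 to compound 4 (0.13 log units; within the scatter), so this first comparison of two pyridinyl isomers at this nitrogen does not separate them. The earlier step at the same nitrogen, a 3.1-fold lower number from compound 1 to compound 2 (0.50 log units; beyond the scatter), set methyl against pyridin-3-yl and could not show whether the choice of pyridinyl isomer matters; with the (4-methylpiperazin-1-yl)methyl group on the core, this pair shows no effect of that choice beyond the scatter. No accompanying measurement bears on this result, which therefore stands as an observation in this one assay.

Still open, on these data alone, is how pyridin-2-yl, or a plain phenyl ring, would read on this amide-type nitrogen, since either would show whether the pyridinyl nitrogen is needed at all. Also open is whether the two isomers would still read alike without the (4-methylpiperazin-1-yl)methyl group, as the only comparison of them carries it and compound 2 , at 27 nM, has no pyridin-4-yl counterpart among the compounds shown.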